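This account rests on a few compounds, and the source may have more. Where it says the series, first, only, none or still open, it means among the compounds named here.

Compound 1 `CCCSc1nc(N)c2nc(O)n(Cc3ccccc3)c2n1`: 0.01 uM in a functional assay (spleen, spleen) for activation, with Mus musculus as the target; on this read-out higher numbers stand for an effect only at larger amounts of compound and lower numbers for an effect already at smaller amounts
Compound 2 `Nc1ncnc2c1nc(Cl)n2Cc1ccccc1`: > 10 uM, a limit of the assay
Compound 3 `CSc1nc2c(N)ncnc2n1Cc1ccccc1`: > 10 uM, also a limit of the assay

Among these three results compound 1 is the only one reported as a number; the other two sit at the limit (the limit of > 10 uM in this assay, at which 2 of the 3 values shown sit). The step that the two limits leave unreadable from compound 2 to compound 3 is accordingly unreadable. Compound 4 `CCCCCOc1nc(N)c2nc(O)n(Cc3ccccc3)c2n1` differs from compound 1 in one place: pentyloxy in place of propylsulfanyl on an aromatic carbon. No measured step touches this position, and the single measured step gives no readable size, so the shown compounds offer no ground for a shift beyond the scatter in either direction. Compound 4 is therefore expected to give about 0.03 uM, with a range from 0.003 uM to 0.3 uM. The estimated step of a 3.0-fold higher number from compound 1 to compound 4 (0.48 log units; beyond the scatter) is expected to stay within the usual scatter.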

Compound 4, minimum effective concentration: 0.01 uM
For compound 4 the middle estimate is 3.0-fold (0.48 log units) above the measured one; the measured number falls inside the stated range.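

In this assay, for the compounds shown here, the swap of propylsulfanyl for pentyloxy gives the first readable step at this position, on the aromatic carbon between two ring nitrogen atoms: no change at the digits printed from compound 1 to compound 4 (within the scatter). The position therefore carries either an oxygen-linked or a sulfur-linked chain on the shared core with the read-out unmoved, even though the entering group has more heavy atoms. The atom and the chain changed in the same step, so their separate contributions cannot be told apart.

As far as these compounds go, whether an amine, a butyloxy chain or a carboxylic acid at this position would keep the value stays open. Nothing shown here explains why the two groups read alike.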